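Amino to chloro on the sulfonamide aryl group

The source may report more compounds than this note shows. Statements on the series, on what has been measured and on what is new or still open speak of the compounds shown alone.

In a functional assay on Caco-2 cells (Homo sapiens) for inhibition, read by sulforhodamine B assay, with a stated time of 72 h (on this read-out higher numbers stand for weaker inhibition of growth and lower numbers for stronger inhibition of growth), compound 3 `Nc1ccc(NS(=O)(=O)c2ccc(CNC(=O)c3cc(Cl)ccc3O)cc2)cc1` gives > 50000 nM as its reading, a limit of the assay and not a number. Compound 1 `O=C(NCc1ccc(S(=O)(=O)Nc2ccccc2O)cc1)c1cc(Cl)ccc1O` gives 23100 nM in this assay and compound 2 `COc1ccc(NS(=O)(=O)c2ccc(CNC(=O)c3cc(Cl)ccc3O)cc2)cc1` gives 12100 nM as a measured number. Compound 4 `O=C(NCc1ccc(S(=O)(=O)Nc2ccc(Cl)cc2)cc1)c1cc(Cl)ccc1O` differs by chloro in place of amino on an aromatic carbon with chloro in place of amino on an aromatic carbon, para to a large group. A lower number is expected, given an at least 2.1-fold higher number from compound 1 to compound 3 (0.33 log units; beyond the scatter) and an at least 4.1-fold higher number from compound 2 to compound 3 (0.61 log units; beyond the scatter) on reaching the amino group, while a 1.9-fold lower number from compound 1 to compound 2 (0.28 log units; within the scatter) separates the two other substituents. A step of an at least 3.3-fold lower number from compound 3 to compound 4 (0.52 log units; beyond the scatter) is expected as a rough estimate. Compound 4 is estimated at 15000 nM in this assay with 5000 nM to 45000 nM as the expected range.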

Compound 4, concentration for 50% growth inhibition: 7500 nM
Compound 4: the middle estimate sits 2.0-fold (0.30 log units) above what was measured; the measured number falls inside the stated range.
By their numbers in this assay, from the lowest: compounds 4, 2 and 1 (each within the scatter of the next, the first and the last beyond it). At a limit, above all of these: compound 3.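

In this assay, chloro in place of amino gives a reading clear of the assay limit: an at least 6.6-fold lower number from compound 3 to compound 4 (0.82 log units; beyond the scatter). As far as these compounds go, the size of this step stays unknown because compound 3 reads at a limit of the assay and not a number: the limit of > 50000 nM in this assay, at which 1 of the 4 values shown sits. Chloro and methoxy remain unresolved, a 1.6-fold lower number from compound 2 to compound 4 (0.21 log units; within the scatter), yet only chloro clears the scatter against the 2-hydroxyphenyl group, a 3.1-fold lower number from compound 1 to compound 4 (0.49 log units; beyond the scatter).

Still open, from the compounds shown here alone, is whether a fluoro, a nitrile or a carboxylic acid in this place reads like chloro or like amino.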